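This account rests on a few compounds, and the source may have more. Where it says the series, first, only, none or still open, it means among the compounds named here.

Measured compounds in a functional assay on U-373MG ATCC cells (Homo sapiens) for inhibition, read by MTT assay, with a stated time of 72 h; on this read-out higher numbers stand for weaker inhibition and lower numbers for stronger inhibition:

- compound 1, `CC1(C)CC(NC(=S)Nc2cccc(C#N)c2)c2cc(Cl)ccc2O1`: 7000 nM
- compound 2, `CC1(C)CC(NC(=S)Nc2ccc(C#N)cc2)c2cc(Cl)ccc2O1`: 10000 nM
- compound 3, `CCNC(=S)NC1CC(C)(C)Oc2ccc(Cl)cc21`: 96000 nM

Compound 2 holds the second highest of the three numbers in this assay. Its nearest neighbour is compound 1, with a 1.4-fold higher number from compound 1 to compound 2 (0.15 log units; within the scatter); the two are not distinguishable on this read-out. Its furthest neighbour is compound 3, with a 9.6-fold higher number from compound 2 to compound 3 (0.98 log units; beyond the scatter), and the gap from compound 1 is larger still, a 14-fold higher number from compound 1 to compound 3 (1.14 log units; beyond the scatter). Both of these larger steps come from putting ethyl in place of a cyanophenyl group on the amide-type nitrogen; the step between the two cyanophenyl isomers is small.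

Compound 4, `CC1(C)CC(NC(=S)Nc2ccc(C#N)cc2)c2cc(Br)ccc2O1`, is yet to be measured in this assay. It differs from compound 2 as follows: bromo in place of chloro on an aromatic carbon. For the measured compounds named here, none of the measured steps touches this position; all three vary the group on the amide-type nitrogen, so there is no direct precedent for a halogen swap on the fused aromatic ring. Without such a precedent, the working expectation is a step that stays within the scatter, in either direction.

Compound 4 is therefore expected to give about 10000 nM in this assay, with a plausible range of 4000 nM to 25000 nM. This estimate corresponds to no change at the digits printed from compound 2 to compound 4 (within the scatter), which is expected to lie within the scatter.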

Compound 4, half-maximal inhibitory concentration: 22000 nM
The estimate for compound 4 lay 2.2-fold (0.34 log units) below the measured number; low and high end bracket the measured number.
By their numbers in this assay, from the lowest: compounds 1 and 2 (each within the scatter of the next); then compound 4; then compound 3.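

For the compounds shown here, the halogen on the fused aromatic ring is not a silent position in this assay: bromo in place of chloro gives a 2.2-fold higher number from compound 2 to compound 4 (0.34 log units; beyond the scatter) and is the first step from outside the amide-type nitrogen. That step is modest beside the one for ethyl in place of 4-cyanophenyl, a 9.6-fold higher number from compound 2 to compound 3 (0.98 log units; beyond the scatter), so among the compounds shown the group on that nitrogen moves the number further than this halogen swap does. No measurement at hand accounts for the higher number with bromo, and this single pair ties the step to no property of either halogen.

The swap is shown only with the 4-cyanophenyl group, so whether a step of this size carries over to the 3-cyanophenyl group of compound 1 or to the ethyl group of compound 3 stays open. Also open, from the compounds shown here alone, is how fluoro, methoxy or an amine on this same aromatic carbon would read, and whether the number would keep moving in the same direction with any of them.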